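Hydroxymethyl for Ester on a Second Acrylamide Core

This account rests on a few compounds, and the source may have more. Where it says the series, first, only, none or still open, it means among the compounds named here.

Of the compounds shown here, three have been measured so far. Compound 1 `C=CC(=O)Nc1ccc(Cn2nc(-c3ccc(Oc4ccccc4)cc3)cc2C(=O)OCC)cc1` gives 10900 nM in a functional assay on JeKo-1 cells (Homo sapiens) for inhibition, read by luminescence and CellTiter-Glo, with a stated time of 72 h; a higher number here means a weaker inhibitor, a lower number a stronger inhibitor. Compound 2 `C=CC(=O)Nc1cccc(Cn2nc(-c3ccc(Oc4ccccc4)cc3)cc2C(=O)OCC)c1` gives 7600 nM in this assay. The two cores are built from the same atoms joined differently, the difference being (3-((vinylcarbonyl)amino)phenyl in place of 4-((vinylcarbonyl)amino)phenyl on a saturated chain carbon bound to an aromatic nitrogen), and the step between them is a 1.4-fold lower number from compound 1 to compound 2 (0.16 log units; within the scatter). Compound 3 `C=CC(=O)Nc1ccc(Cn2nc(-c3ccc(Oc4ccccc4)cc3)cc2CO)cc1` gives 8000 nM in this assay. It differs from compound 1 by hydroxymethyl in place of ethoxycarbonyl on an aromatic carbon, and the step there is a 1.4-fold lower number from compound 1 to compound 3 (0.13 log units; within the scatter). All three numbers sit within the usual scatter of one another, so no order among them can be claimed.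

Compound 4 `C=CC(=O)Nc1cccc(Cn2nc(-c3ccc(Oc4ccccc4)cc3)cc2CO)c1` has not yet been measured. It differs from compound 2 by hydroxymethyl in place of ethoxycarbonyl on an aromatic carbon, and its place description matches that of the change from compound 1 to compound 3 word for word; the same change thus appears twice, once on each core. Within the data shown here, only one measured example of this change exists, so the expectation rests on a single step. The step is expected to be a 1.3-fold lower number from compound 2 to compound 4 (0.12 log units; within the scatter), because the earlier instance was a 1.4-fold lower number from compound 1 to compound 3 (0.13 log units; within the scatter) and a change that stayed within the scatter once is expected to stay within it again. Compound 4 is therefore estimated at 5800 nM in this assay, with a plausible range from 2500 nM to 13000 nM.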

Compound 4, half-maximal inhibitory concentration: 5200 nM
Beside the measured number, compound 4's estimate is 1.1-fold (0.05 log units) above it, within the range that was stated.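

In this assay, putting hydroxymethyl in place of ethoxycarbonyl on the core of compound 2 gives a 1.5-fold lower number from compound 2 to compound 4 (0.16 log units; within the scatter), so removing this ester from a second core leaves the number within the usual spread of repeat measurements. Set beside the earlier example, the change behaves alike on both cores, with no difference that can be told apart from scatter: the same change on two cores in this assay, a 1.4-fold lower number (0.13 log units; within the scatter) from compound 1 to compound 3 and a 1.5-fold lower number (0.16 log units; within the scatter) from compound 2 to compound 4, 1.1-fold (0.03 log units) apart, within the scatter of two such steps. This agreement shows that the small size of the step carried over from one core to the other, but neither step is large enough to show that hydroxymethyl gives a stronger inhibitor than ethoxycarbonyl, and two cores in one assay say nothing about how the change would behave on any other core.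

The compounds shown leave open whether any group on this aromatic carbon of the five-membered ring could move the number beyond the scatter, for example a carboxylic acid, a primary amide, an aminomethyl group or a longer chain such as hydroxyethyl. They also leave open whether either core would respond in the same way to such a group, since a shared small step does not predict how the two cores would behave under a larger change.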